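The compounds below may be only part of what the source reports. "The series", "measured", "known", "first", "only" and "open" are said of these compounds alone.

Measured in an ADME assay for permeability, using PAMPA, with a stated time of 30 min, at pH 7.4; on this read-out higher numbers stand for higher permeability and lower numbers for lower permeability:

compound 1 `Fc1ccc(Oc2ccc3c(NCCCNCc4ccco4)ccnc3c2)cc1`: 317 10^-6 cm/s
compound 2 `CCC(CC)c1ccc2c(NCCCNCc3cccc(OC)c3O)ccnc2c1`: 23 10^-6 cm/s
compound 3 `Cc1cc(C)cc(Cc2ccc3c(NCCCNCc4ccco4)ccnc3c2)c1`: 23 10^-6 cm/s

Compound 2 sits at the bottom of the three numbers, level with compound 3 at the digits shown, within the scatter; compound 1 stands well above both, beyond the scatter. Within the data shown here, the one step between measured compounds that differ in a single place is a 14-fold lower number from compound 1 to compound 3 (1.14 log units; beyond the scatter), an exchange of one group on an aromatic carbon of the shared core, where a 4-fluorophenoxy went out and a 3,5-dimethylbenzyl came in.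

Compound 4 `COc1cccc(CNCCCNc2ccnc3cc(CC4CCCCC4)ccc23)c1O` is not yet measured. Against compound 2 it carries cyclohexylmethyl in place of pentan-3-yl on an aromatic carbon. Among the measured compounds shown here, this is the same kind of position as in the measured step, an aromatic carbon of the core, but the groups exchanged are both hydrocarbon, without donors or acceptors, and no measured pair shows a swap of this sort. The large step from compound 1 to compound 3 involved an ether oxygen leaving, which does not apply here. With nothing closer to lean on, the expectation for compound 4 in this assay is a step of a 1.1-fold higher number from compound 2 to compound 4 (0.04 log units; within the scatter), not beyond the scatter. Compound 4 is therefore estimated at 25 10^-6 cm/s, in a range from 10 10^-6 cm/s to 65 10^-6 cm/s.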

Compound 4, apparent permeability: 23 10^-6 cm/s
Beside the measured number, compound 4's estimate is 1.1-fold (0.04 log units) above it, within the range that was stated.
By their numbers in this assay, from the lowest: compounds 2, 3 and 4 (each within the scatter of the next); then compound 1.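

In this assay, the exchange of pentan-3-yl for cyclohexylmethyl on the aromatic carbon gives no change at the digits printed from compound 2 to compound 4 (within the scatter), so at this position a ring of carbon only and the larger count of 7 heavy atoms leave the two compounds unseparated. Among these compounds, until now the only reading at this kind of position was a 14-fold lower number from compound 1 to compound 3 (1.14 log units; beyond the scatter), and that step alone suggested a position where any exchange might move the number a long way; the new pair shows that at least one exchange between groups without hydrogen-bond donors or acceptors does not. Nothing available explains why the two groups read alike.

From the compounds shown here alone, compound 1 and compound 3 differ from compound 2 and compound 4 elsewhere as well, so it remains open whether the 4-fluorophenoxy group would stand out in the same way on the core of compound 2. Also open is what a carboxylic acid, a morpholine or a primary amine on this aromatic carbon would do in this assay, since the pairs shown cover only uncharged groups there.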